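The compounds below may be only part of what the source reports. "The series", "measured", "known", "first", "only" and "open" are said of these compounds alone.

In a functional assay with Felis catus as the target (a lower number here means that less compound is needed, a higher number that more compound is needed for the effect), compound 1 (`Cc1nc(O)c(C#N)c(NCc2ccccn2)n1`) gives 180000 nM and compound 2 (`Cc1nc(O)c(C#N)c(NCc2ccco2)n1`) gives 88000 nM as the lower of the two numbers. Compound 3 (`CCNc1nc(C)nc(O)c1C#N`) carries methyl in place of furan-2-yl on a saturated chain carbon bound to a nitrogen on an aromatic ring. Among the compounds with values here, the only measured step at this place is modest (a 2.0-fold lower number from compound 1 to compound 2 (0.31 log units; beyond the scatter)) and swaps one ring for another. Within the data shown here, no measured compound lacks a ring there, so the direction remains uncertain. The estimated step in this assay is of similar modest size and towards a higher number (a 2.3-fold higher number from compound 2 to compound 3 (0.36 log units; beyond the scatter)). For compound 3 the expected value is 200000 nM with an estimated range from 70000 nM to 500000 nM as its bounds.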

Compound 3, half-maximal effective concentration: 300000 nM
Compound 3: the middle estimate sits 1.5-fold (0.18 log units) below what was measured, and the stated range covers the measured number.
By their numbers in this assay, from the lowest: compound 2; then compounds 1 and 3 (each within the scatter of the next).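

Within the data shown here, compound 3 alone has no ring at this place, and the result gives the first comparison of rings with a plain methyl. In this assay, replacing furan-2-yl with methyl gives a step beyond the scatter (a 3.4-fold higher number from compound 2 to compound 3 (0.53 log units; beyond the scatter)), whereas replacing pyridin-2-yl with methyl gives one within it (a 1.7-fold higher number from compound 1 to compound 3 (0.22 log units; within the scatter)), so having a ring here does not by itself separate a compound from methyl. Nothing available explains this difference between the two rings. On these data alone, whether a longer chain or a phenyl ring at this place would match furan-2-yl remains open.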